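A Dihydroxyphenyl Replaces Methoxyphenyl in a Cytotoxicity Series

The source may report more compounds than this note shows. Statements on the series, on what has been measured and on what is new or still open speak of the compounds shown alone.

Compound 3 `COc1ccc(/C=C2\CCC/C(=C\c3cccc(OC)c3OC)C2=O)cc1` carries the highest number of the three in a functional assay on HT-1080 cells (Homo sapiens) for cytotoxicity, read by MTT assay, with a stated time of 72 h (a higher number here means a weaker inhibitor, a lower number a stronger inhibitor), where compound 3 gives 16300 nM; yet compound 2 `COc1ccccc1/C=C1\CCC/C(=C\c2cccc(OC)c2OC)C1=O` with 14100 nM and compound 1 `COc1cccc(/C=C2\CCC/C(=C\c3ccccc3Br)C2=O)c1OC` with 10800 nM both lie within the scatter of it, so no order among the three can be claimed. Compound 4 `COc1cccc(/C=C2\CCC/C(=C\c3ccc(O)c(O)c3)C2=O)c1OC` differs from compound 3 in one place: 3,4-dihydroxyphenyl in place of 4-methoxyphenyl on a double-bonded chain carbon bound to a double-bonded ring carbon. For the measured compounds named here, the steps that bear on this place are a 1.5-fold higher number from compound 1 to compound 3 (0.18 log units; within the scatter) and a 1.2-fold higher number from compound 2 to compound 3 (0.06 log units; within the scatter), both small. Going by the values given here, no measured pair exchanges a methoxy for hydroxyls, so the expected step is a 1.4-fold lower number from compound 3 to compound 4 (0.13 log units; within the scatter), none beyond the scatter. Compound 4 is therefore estimated at 12000 nM, with a range from 4000 nM to 35000 nM.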

Compound 4, half-maximal inhibitory concentration: 4700 nM
Compound 4: middle estimate off by 2.6-fold (0.41 log units), on the high side, and the stated range covers the measured number.
By their numbers in this assay, from the lowest: compound 4; then compounds 1, 2 and 3 (each within the scatter of the next).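

In this assay, the steps at this place had stayed within the scatter, but 3,4-dihydroxyphenyl gives a 3.5-fold lower number from compound 3 to compound 4 (0.54 log units; beyond the scatter) and a 3.0-fold lower number from compound 2 to compound 4 (0.48 log units; beyond the scatter) and a 2.3-fold lower number from compound 1 to compound 4 (0.36 log units; beyond the scatter). So the group on this double-bonded chain carbon can shift the number measurably, and all three groups replaced here point the same way. Nothing at hand explains the shift. Whether both hydroxyls are needed stays open, since no compound shown carries a single one, and so does whether an amine on that ring would give a similar step.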